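This account rests on a few compounds, and the source may have more. Where it says the series, first, only, none or still open, it means among the compounds named here.

Measured compounds in a functional assay on HT-29 cells (Homo sapiens) for antiproliferative activity, read by sulforhodamine B assay, with a stated time of 48 h; on this read-out higher numbers stand for weaker inhibition and lower numbers for stronger inhibition:
- compound 1 `Cc1cccc(NS(=O)(=O)c2ccc(N3CCNC3=O)cc2)c1` gives 110 nM
- compound 2 `Cc1ccc(NS(=O)(=O)c2ccc(N3CCNC3=O)cc2)cc1C` gives 230 nM
- compound 3 `O=C1NCCN1c1ccc(S(=O)(=O)Nc2ccc(Cl)cc2)cc1` gives 220 nM

Among these three numbers compound 3 stands second highest in this assay; its nearest neighbour is compound 2, with a 1.0-fold lower number from compound 2 to compound 3 (0.02 log units; within the scatter), and its furthest is compound 1, with a 2.0-fold higher number from compound 1 to compound 3 (0.30 log units; within the scatter), both of them within the scatter. Compound 4 `Cc1ccc(C)c(NS(=O)(=O)c2ccc(N3CCNC3=O)cc2)c1` has not yet been measured. It differs from compound 3 in one place: 2,5-dimethylphenyl in place of 4-chlorophenyl on a sulfonamide nitrogen.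

Two of the measured steps bear on this change. Exchanging one aryl group on the sulfonamide nitrogen for another gave a 2.0-fold higher number from compound 1 to compound 3 (0.30 log units; within the scatter) and a 1.0-fold lower number from compound 2 to compound 3 (0.02 log units; within the scatter), neither beyond the scatter. Adding a methyl on an aromatic carbon gave a 2.1-fold higher number from compound 1 to compound 2 (0.32 log units; beyond the scatter), a modest step just beyond it. On that basis compound 4 is expected to sit close to compound 3, with an estimated step of a 1.1-fold lower number from compound 3 to compound 4 (0.04 log units; within the scatter), not beyond the scatter. The estimate for compound 4 in this assay is 200 nM, with a range from 80 nM to 600 nM.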

Compound 4, half-maximal inhibitory concentration: 46 nM
Compound 4: middle estimate off by 4.3-fold (0.64 log units), on the high side; measured number outside the range, below it.
By their numbers in this assay, from the lowest: compound 4; then compounds 1, 3 and 2 (each within the scatter of the next, the first and the last beyond it).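

In this assay, the aryl group on the sulfonamide nitrogen now moves the number clearly beyond the scatter, where the earlier exchanges at this place barely reached it: 2,5-dimethylphenyl in place of 4-chlorophenyl gives a 4.8-fold lower number from compound 3 to compound 4 (0.68 log units; beyond the scatter), and in place of 3,4-dimethylphenyl it gives a 5.0-fold lower number from compound 2 to compound 4 (0.70 log units; beyond the scatter). Adding a methyl to the aryl group of compound 1 can also go either way, with a 2.4-fold lower number from compound 1 to compound 4 (0.38 log units; beyond the scatter) against a 2.1-fold higher number from compound 1 to compound 2 (0.32 log units; beyond the scatter), so among these compounds that change has no single direction. Nothing available accounts for this difference between the two dimethylphenyl groups.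

The compounds shown leave open whether a methoxy group or an amine on this aryl ring, or a plain alkyl chain in its place, would lower the number further. They also leave open how changes to the shared core would affect it.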